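Replacing isopropylphenyl with dichlorophenyl in compound 1

The source may hold more compounds than are shown below. What is called first, only, known or untested is meant among the compounds shown, and "the series" means these compounds.

Compound 1 `CCCc1cc(N)c2cc(NC(=O)/C=C/c3ccc(C(C)C)cc3)ccc2n1` was tested in an assay on isolated protein for displacement of a labelled ligand from melanin-concentrating hormone receptor 1 (Homo sapiens) (a lower number here means a stronger inhibitor, a higher number a weaker inhibitor), where compound 1 gives 2.9 nM. Among the three measured compounds it stands second highest: compound 3 `CCCc1cc(NC)c2cc(NC(=O)/C=C/c3ccc(C(F)(F)F)cc3)ccc2n1` gives 1.5 nM in this assay, a gap to compound 1 that lies within the usual scatter, while compound 2 `CCCCc1ccc(/C=C/C(=O)Nc2ccc3nc(CCC)cc(N)c3c2)cc1` gives 45 nM. Among the compounds with values here, the only single-point step in this set runs a 16-fold higher number from compound 1 to compound 2 (1.19 log units; beyond the scatter), so a change of the group on the aromatic carbon can move the number far beyond the scatter.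

Compound 4 `CCCc1cc(N)c2cc(NC(=O)/C=C/c3ccc(Cl)c(Cl)c3)ccc2n1` has not yet been measured in this assay. It differs from compound 1 by 3,4-dichlorophenyl in place of 4-isopropylphenyl on a double-bonded chain carbon bound to a double-bonded chain carbon. Within the data shown here, no measured step covers this particular exchange; the step from compound 1 to compound 2 shows only that altering the group on that aromatic ring can cost a large amount, and compounds 1 and 3, which carry different groups there, give numbers within the scatter of each other. Because compound 1 sits at 2.9 nM and the measured steps point in both directions, the expected step is a 1.4-fold higher number from compound 1 to compound 4 (0.14 log units; within the scatter), which is small. Compound 4 is therefore estimated at 4 nM, with a range from 1 nM to 15 nM.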

Compound 4, half-maximal inhibitory concentration: 60 nM
Compound 4: the middle estimate sits 15-fold (1.18 log units) below what was measured; the whole stated range lies below it.
By their numbers in this assay, from the lowest: compounds 3 and 1 (each within the scatter of the next); then compounds 2 and 4 (each within the scatter of the next).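

In this assay the exchange of 4-isopropylphenyl for 3,4-dichlorophenyl gives a 21-fold higher number from compound 1 to compound 4 (1.32 log units; beyond the scatter), so this position is sensitive not only to a butyl group, as the earlier step showed, but also to a change of the whole substitution on the ring. With a 16-fold higher number from compound 1 to compound 2 (1.19 log units; beyond the scatter) alongside it, both single-place changes from compound 1 at this ring now go the same way and beyond the scatter, and compounds 2 and 4 lie within the scatter of each other; compound 3 stands apart from this pattern, with a number within the scatter of compound 1, but it also differs from compound 1 at the amine and cannot be read as a change at this ring alone. Nothing measured here explains the loss for compound 4.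

The compounds shown leave open whether the loss comes from losing the isopropyl group or from gaining the two chlorines. A phenyl ring carrying a single chlorine, or a tert-butyl group in place of the isopropyl, would separate these two readings.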